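This account rests on a few compounds, and the source may have more. Where it says the series, first, only, none or still open, it means among the compounds named here.

Measured so far:
- Compound 1 `Cc1cc(NC(=S)Cn2nnc(-c3ccccc3)n2)n(C2CCCCC2)n1`: in an assay on HEK293 cells for activation of Kir3.1/Kir3.2 (Homo sapiens), read by thallium flux (a higher number here means that more compound is needed for the effect, a lower number that less compound is needed), compound 1 gives 623 nM.
- Compound 2 `CCC(C)n1nc(C)cc1NC(=O)Cn1nnc(-c2ccccc2)n1`: in this assay compound 2 gives > 5000 nM.

Compound 2 stands at the edge of what this assay reports. The value > 5000 nM for compound 2 is a limit of the assay, not a measured number. Of the two values shown, one sits at that limit (the limit of > 5000 nM in this assay, at which 1 of the 2 values shown sits). Among the measured compounds shown here, compound 1 and compound 2 differ in more than one place, so no single step connects them; their two values show only that compound 1 was resolved as a number and compound 2 was not.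

The step to compound 3 `Cc1cc(NC(=O)Cn2nnc(-c3ccccc3)n2)n(-c2ccccc2)n1` is phenyl in place of sec-butyl on an aromatic nitrogen. For the measured compounds named here, no measured pair covers this change, so its size has to be guessed. The expected direction is toward lower numbers, since compound 2 can only improve from a limit, but the size is uncertain: a moderate drop is expected, with a real chance that compound 3 also returns only a limit. Compound 3 is expected to give about 2500 nM in this assay, with a likely range from 700 nM to 9000 nM. The expected step is an at least 2.0-fold lower number from compound 2 to compound 3 (0.30 log units; that floor lies within the scatter).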

Compound 3, half-maximal effective concentration: 3020 nM
Estimate against measurement, compound 3: 1.2-fold (0.08 log units) below, within the range that was stated.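

In this assay compound 3 gives 3020 nM, so with phenyl on the aromatic nitrogen the assay resolves a number, which sec-butyl in compound 2 did not yield. On these data alone, the value of compound 2, > 5000 nM, is a limit of the assay and not a number, so the change at this position can be read only as an at least 1.6-fold lower number from compound 2 to compound 3 (0.21 log units; that floor lies within the scatter), and its true size stays unknown. The step has only a floor because one of its ends sits at a limit: the limit of > 5000 nM in this assay, at which 1 of the 3 values shown sits.

Compound 1, at 623 nM, differs from compound 3 in more than one place, so the values shown cannot say how much of what separates them belongs to the group on the aromatic nitrogen and how much to the rest of the molecule. As far as these compounds go, it also remains open what a benzyl group or a short chain such as ethyl would give on that same aromatic nitrogen, and whether phenyl is matched or passed by either of them.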